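Methoxycarbonyl to Carboxy: Expecting Compound 3

The source may report more compounds than this note shows. Statements on the series, on what has been measured and on what is new or still open speak of the compounds shown alone.

Measured so far:
compound 1 `COC(=O)CCCC[C@H](NC(=O)OC(C)(C)C)C(=O)NC1CCCC1`: 40%
compound 2 `COC(=O)CCCCC[C@H](NC(=O)OC(C)(C)C)C(=O)NC1CCCC1`: 60%

In an assay on isolated protein for inhibition of protein deacetylase HDAC6 (Homo sapiens), read by fluorescence, tested at 1 uM (a higher number here means more inhibition at the concentration tested (going by the name of the read-out), a lower number less inhibition), compound 2 gives 60%, the highest of the two numbers, and the gap to compound 1 lies beyond the scatter. Within the data shown here, the only measured step, a number 20 percentage points higher from compound 1 to compound 2 (beyond the scatter), is a change of chain length. Compound 3 `CC(C)(C)OC(=O)N[C@@H](CCCCCC(=O)O)C(=O)NC1CCCC1` differs from compound 2 by hydrogen in place of methyl on an oxygen next to a carbonyl group. Among the measured compounds shown here, no measured step touches this oxygen, so the data offer no direct guide to this change. The step from compound 2 to compound 3 is therefore expected to be small, a number 10 percentage points lower from compound 2 to compound 3 (within the scatter), within the scatter. Compound 3 is estimated at 50%, with a range from 20% to 80%.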

Compound 3, a percentage reported as inhibition, at one concentration (the size of the read-out at that concentration, not a potency): 45%
For compound 3 the middle estimate is 5 percentage points above the measured one; measured number inside the range.
By their numbers in this assay, from the lowest: compounds 1 and 3 (each within the scatter of the next); then compound 2.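

Among these compounds, the first change at the chain end itself, methoxycarbonyl to carboxy, does register in this assay: there is a number 15 percentage points lower from compound 2 to compound 3 (beyond the scatter) when hydrogen replaces methyl on this oxygen. Set against the shorter ester, carboxymethyl gives a number 5 percentage points higher from compound 1 to compound 3 (within the scatter) in place of methoxycarbonyl, so the two cannot be told apart here. Nothing available explains these shifts.

Still open, as far as these compounds go, is how carboxy would read on the shorter chain of compound 1. Also open, from the compounds shown here alone, is how a hydroxamic acid or a primary amide at the chain end would compare.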